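The source may report more compounds than this note shows. Statements on the series, on what has been measured and on what is new or still open speak of the compounds shown alone.

Measured so far in an ADME assay on microsomes from liver (Mus musculus) for metabolic stability, with a stated time of 10 min, tested at 0.5 uM; on this read-out higher numbers stand for a more stable compound and lower numbers for a less stable compound:
- compound 1 `CCC(Nc1nnc(-c2ccc(OC)cc2)o1)[C@H]1CC[C@@H](c2ccnc3ccc(F)cc32)CC1`: 31%
- compound 2 `CCOCC(Nc1nnc(-c2ccc(OC)cc2)o1)[C@H]1CC[C@@H](c2ccnc3ccc(C(F)(F)F)cc32)CC1`: 41%
- compound 3 `C[C@@H](c1nc2ccc(Cl)cc2[nH]1)[C@H]1CC[C@@H](c2ccnc3ccc(F)cc32)CC1`: 12%

Compound 2 holds the highest of the three numbers in this assay; the nearest, compound 1, sits within the usual scatter of it, so no order between those two is claimed, whereas compound 3 sits beyond the scatter below compound 2. Compound 4 `CCC(Nc1nnc(-c2ccc(OC)cc2)o1)[C@H]1CC[C@@H](c2ccnc3ccc(C(F)(F)F)cc32)CC1` has not been measured. Against compound 2 it shows (methyl in place of ethoxy on a saturated chain carbon, two bonds along the chain from a nitrogen on an aromatic ring and a saturated ring carbon). Among the compounds with values here, no measured pair differs in just this one place, so the step cannot be read off directly; compound 1 carries the same ethyl as compound 4 and gives a number within the scatter of compound 2. The step is expected to be small, a number 6 percentage points lower from compound 2 to compound 4 (within the scatter), likely not beyond the scatter and, if anything, downward. Compound 4 is therefore estimated at 35% in this assay, with a range from 18% to 55%.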

Compound 4, percent of the compound remaining: 39%
Estimate against measurement, compound 4: 4 percentage points below, within the range that was stated.
By their numbers in this assay, from the lowest: compound 3; then compounds 1, 4 and 2 (each within the scatter of the next).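

In this assay, methyl in place of ethoxy on this saturated chain carbon gives a number 2 percentage points lower from compound 2 to compound 4 (within the scatter) on the shared core, so this position tolerates the ethoxymethyl to ethyl change without a step beyond the scatter. With the ethyl held constant, trifluoromethyl in place of fluoro on an aromatic carbon gives a number 8 percentage points higher from compound 1 to compound 4 (within the scatter) and likewise stays inside the scatter. No measurement available here explains either step.

Open, as far as these compounds go, is whether an amine, a carboxylic acid or a longer chain on this carbon would give a step beyond the scatter. Also open, from the compounds shown here alone, is whether the trifluoromethyl to fluoro comparison holds with the ethoxymethyl chain in place.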